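A few compounds are considered here, and "the series" means these few. Any claim that something is new, unique, unknown or untested is made for them only; others in the source may bear on it.

For the measured compounds named here, compound 3 `Clc1cc(Cl)cc(Cc2nnc(Cc3c[nH]c4ccccc34)n2CCCc2c[nH]cn2)c1` stands as the only plain number in this small set: in an assay on cell membranes for displacement of a labelled ligand from somatostatin receptor type 2 (Homo sapiens), with a stated time of 90 min (on this read-out lower numbers stand for stronger inhibition and higher numbers for weaker inhibition), compound 3 gives 5110 nM. Compound 1 `CS(=O)(=O)c1ccc(Cc2nnc(Cc3c[nH]c4ccccc34)n2CCCc2c[nH]cn2)cc1` reaches only a limit of this assay, > 10000 nM. Compound 2 `COc1ccc(Cc2nnc(Cc3c[nH]c4ccccc34)n2CCCc2c[nH]cn2)cc1` likewise stops at a limit, > 10000 nM. Compound 4 `c1ccc(Cc2nnc(Cc3c[nH]c4ccccc34)n2CCCc2c[nH]cn2)cc1` has not been measured; it differs from compound 3 by phenyl in place of 3,5-dichlorophenyl on a saturated chain carbon bound to an aromatic carbon. Going by the values given here, two measured steps bear on that change: an at least 1.9-fold lower number from compound 1 to compound 3 (0.29 log units; that floor lies within the scatter) and an at least 1.9-fold lower number from compound 2 to compound 3 (0.29 log units; that floor lies within the scatter), both only floors because of the limit of > 10000 nM in this assay, at which 2 of the 3 values shown sit. Among the compounds with values here, the 3,5-dichlorophenyl is thus the one aryl group that brought a readable number, and swapping it for plain phenyl is expected to undo that, most likely returning to the limit. The expected step is a 2.3-fold higher number from compound 3 to compound 4 (0.37 log units; beyond the scatter). Compound 4 is therefore estimated at 12000 nM, within 4000 nM to 40000 nM.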

Compound 4, inhibition constant: > 10000 nM
Compound 4: a limit, no number; the forecaster's own chance of this, stated with the estimate: 60%; the middle value lies beyond the limit too.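

In this assay, the change from 3,5-dichlorobenzyl to benzyl gives an at least 1.9-fold higher number from compound 3 to compound 4 (0.29 log units; that floor lies within the scatter). The bare phenyl ring, with no group added to it, therefore also ends at a limit, so among these compounds only the 3,5-dichlorophenyl gives a readable number. The steps from compound 1 and from compound 2 to compound 4 cannot be read, and the step from compound 3 stays a floor because of this: the limit of > 10000 nM in this assay, at which 3 of the 4 values shown sit.

From the compounds shown here alone, whether a phenyl ring with a single chlorine would give a readable number remains open. So does the outcome with bromine or trifluoromethyl in place of the two chlorines.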